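The source may hold more compounds than are shown below. What is called first, only, known or untested is meant among the compounds shown, and "the series" means these compounds.

Compound 1 `CC(=N)N1CCC(Oc2ccc3nc(C)n(Cc4ccc5ccc(C(=N)N)cc5c4)c3c2)CC1` is the parent of this small set; in an assay on isolated protein for inhibition of serine protease 1 (Bos taurus) (on this read-out higher numbers stand for weaker inhibition and lower numbers for stronger inhibition), compound 1 gives 18 nM. Compound 2 `CCCc1nc2ccc(OC3CCN(C(C)=N)CC3)cc2n1Cc1ccc2ccc(C(=N)N)cc2c1` gives 6.8 nM in this assay, and compound 3 `CCc1nc2ccc(OC3CCN(C(C)=N)CC3)cc2n1Cc1ccc2ccc(C(=N)N)cc2c1` gives 7.7 nM. Compound 2 differs from compound 1 by ethyl in place of hydrogen on a saturated chain carbon bound to an aromatic carbon, a change that made a 2.6-fold lower number from compound 1 to compound 2 (0.42 log units; beyond the scatter). Compound 3 differs from compound 1 by methyl in place of hydrogen on a saturated chain carbon bound to an aromatic carbon, with a 2.3-fold lower number from compound 1 to compound 3 (0.37 log units; beyond the scatter). Between the two chain lengths the difference is small: a 1.1-fold higher number from compound 2 to compound 3 (0.05 log units; within the scatter).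

Compound 4 `CCCCc1nc2ccc(OC3CCN(C(C)=N)CC3)cc2n1Cc1ccc2ccc(C(=N)N)cc2c1` has not yet been measured. Within the data shown here, it differs from compound 3 by ethyl in place of hydrogen on a saturated chain carbon, two bonds along the chain from an aromatic carbon, the same kind of change as the one from compound 1 to compound 2, though the place is not the same: there the entering group sits on a saturated chain carbon bound to an aromatic carbon, here on a saturated chain carbon, two bonds along the chain from an aromatic carbon. The two cores themselves differ by methyl in place of hydrogen on a saturated chain carbon bound to an aromatic carbon.

Because a 1.1-fold higher number from compound 2 to compound 3 (0.05 log units; within the scatter) stayed within the scatter, a further lengthening of the chain is expected to matter little, so for compound 4 the estimated step is a 1.2-fold lower number from compound 3 to compound 4 (0.07 log units; within the scatter). Compound 4 is expected to give about 6.5 nM, most likely between 3 nM and 14 nM.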

Compound 4, inhibition constant: 5.7 nM
Compound 4: middle estimate off by 1.1-fold (0.06 log units), on the high side; low and high end bracket the measured number.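

In this assay, ethyl in place of hydrogen on a saturated chain carbon, two bonds along the chain from an aromatic carbon, gave a 1.4-fold lower number from compound 3 to compound 4 (0.13 log units; within the scatter), methyl in place of hydrogen three bonds along gave a 1.2-fold lower number from compound 2 to compound 4 (0.08 log units; within the scatter), and the change from the shortest chain of the set to the longest gave a 3.2-fold lower number from compound 1 to compound 4 (0.50 log units; beyond the scatter). The ethyl change carried from one core to another with no gap beyond the scatter: the same change on two cores in this assay, a 2.6-fold lower number (0.42 log units; beyond the scatter) from compound 1 to compound 2 and a 1.4-fold lower number (0.13 log units; within the scatter) from compound 3 to compound 4, 2.0-fold (0.29 log units) apart, within the scatter of two such steps The methyl change carried over in the same way, but this does not establish a constant step, as each comparison rests on only two cores and the first step of each pair lies beyond the scatter while the second lies within it: the same change on two cores in this assay, a 2.3-fold lower number (0.37 log units; beyond the scatter) from compound 1 to compound 3 and a 1.2-fold lower number (0.08 log units; within the scatter) from compound 2 to compound 4, 2.0-fold (0.29 log units) apart, within the scatter of two such steps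

The compounds shown leave open whether a longer chain such as pentyl or hexyl, or a branched chain such as isopropyl, would fit the same reading in this place. They also leave open whether a chain ending in an amine or a carboxylic acid would do so.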